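Removing a chloro group from a urea-linked aryl ring

The compounds below may be only part of what the source reports. "The series", "measured", "known", "first", "only" and "open" are said of these compounds alone.

Compound 1 `COc1cc(Cl)cc(-c2nn(-c3cccc(NC(=O)Nc4ccc(Cl)c(C(F)(F)F)c4)c3)cc2-c2ccncc2)c1` and compound 2 `COc1cc(Cl)cc(-c2nn(-c3cccc(NC(=O)Nc4cc(C(F)(F)F)cc(C(F)(F)F)c4)c3)cc2-c2ccncc2)c1` share the same core and differ only in the aryl group at the far end of the urea. In a functional assay on RXF 393 cells (Homo sapiens) for inhibition, read by sulforhodamine B assay, with a stated time of 48 h, tested at 0.01 uM (a higher number here means a weaker effect of the compound at the concentration tested, a lower number a stronger effect), compound 1 gives 97%, and in this assay compound 2 gives 96%. Compound 1 has the highest of the two numbers, but the gap to compound 2 lies within the usual scatter, so the two read as alike: at this concentration neither shows much inhibition. Compound 3 `COc1cc(Cl)cc(-c2nn(-c3cccc(NC(=O)Nc4cccc(C(F)(F)F)c4)c3)cc2-c2ccncc2)c1` is not yet measured. It differs from compound 1 by one change: hydrogen in place of chloro on an aromatic carbon. Within the data shown here, no measured pair shows what this change does, so no step beyond the scatter is expected, in either direction. Compound 3 is therefore expected to give 97% in this assay, within 88% to 103%, an estimated step of no change at the digits printed from compound 1 to compound 3 (within the scatter).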

Compound 3, a percentage reported as activity, at one concentration (the size of the read-out at that concentration, not a potency): 93%
The estimate for compound 3 lay 4 percentage points above the measured number; the range from low to high includes it.
By their numbers in this assay, from the lowest: compounds 3, 2 and 1 (each within the scatter of the next).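

Going from the 4-chloro-3-(trifluoromethyl)phenyl ring to the 3-(trifluoromethyl)phenyl ring, in this assay the swap of chloro for hydrogen gives a number 4 percentage points lower from compound 1 to compound 3 (within the scatter) and so leaves the read-out unchanged in any meaningful sense at this position. Hydrogen in place of trifluoromethyl on the same ring gives a number 3 percentage points lower from compound 2 to compound 3 (within the scatter) and so also makes no readable difference, which means that neither change separates these compounds at this low concentration. Nothing measured here offers an explanation for these results.

What the compounds shown leave open is whether a quite different group at this position, such as an amine or a carboxylic acid, would move the read-out beyond the scatter. Going by these compounds, it also remains open whether chloro and hydrogen here would still read as alike at a higher concentration, where inhibition might be stronger.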